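Compound 2 to compound 3: methoxy to ethoxy

A few compounds are considered here, and "the series" means these few. Any claim that something is new, unique, unknown or untested is made for them only; others in the source may bear on it.

In a functional assay on MCF7 cells (Homo sapiens) for inhibition, read by sulforhodamine B assay (a lower number here means a stronger inhibitor, a higher number a weaker inhibitor), compound 1 (`O=C1C(Nc2ccc(Br)cc2)=CC(=O)c2c1nc1n2[C@H]2OC[C@@H](O)[C@H]2OC1`) gives 4330 nM and compound 2 (`COc1ccc(NC2=CC(=O)c3c(nc4n3[C@H]3OC[C@@H](O)[C@H]3OC4)C2=O)cc1`) gives 4470 nM, so the two stand level within the scatter. Compound 3 (`CCOc1ccc(NC2=CC(=O)c3c(nc4n3[C@H]3OC[C@@H](O)[C@H]3OC4)C2=O)cc1`) differs from compound 2 by methyl in place of hydrogen on a saturated chain carbon bound to an oxygen on an aromatic ring, which is methyl in place of hydrogen on a saturated chain carbon bound to an oxygen on an aromatic ring. Within the data shown here, the only measured step, a 1.0-fold higher number from compound 1 to compound 2 (0.01 log units; within the scatter), put methoxy in place of bromo and stayed within the scatter, so no step beyond the scatter is expected in this assay. The estimated step is a 1.0-fold lower number from compound 2 to compound 3 (0.02 log units; within the scatter), which is within the scatter. For compound 3 the expected value is 4300 nM, with an estimated range of 2200 nM to 8000 nM.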

Compound 3, half-maximal inhibitory concentration: > 4000 nM
Compound 3: a limit, no number (the forecaster's own chance of this, stated with the estimate: 3%); the middle value lies beyond the limit too.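

In this assay compound 3 gives > 4000 nM, a limit and not a number. Its steps from compound 1 and compound 2 therefore cannot be read. The compounds shown leave open whether ethoxy in place of methoxy or bromo shifts the number at all.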